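A few compounds are considered here, and "the series" means these few. Any claim that something is new, unique, unknown or untested is made for them only; others in the source may bear on it.

Measured compounds:
Compound 1 `NC(=O)CC[C@H](NC(=O)CN(c1ncnc2c1ncn2C1CCCCO1)C1CC1)C(=O)OCc1ccccc1`: in a functional assay on the whole organism (Tail, strain ICR) with Mus musculus as the target, in the tail flick test, with a stated time of 90 min, at a dose of 25 umol/kg by the oral route (a lower number here means a weaker effect, a higher number a stronger effect of the compound at the dose given), compound 1 gives 37.8%.
Compound 2 `C[C@H](NC(=O)CN(c1nc(Cl)nc2[nH]cnc12)C1CC1)C(=O)OCc1ccccc1`: compound 2 gives 44.2%.
Compound 3 `O=C(CN(c1ncnc2c1ncn2C1CCCCO1)C1CC1)N[C@@H](CCC(=O)OCc1ccccc1)C(=O)OCc1ccccc1`: compound 3 gives 25.2%.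

Compound 3 stands lowest of the three; compound 1 is nearest to it and compound 2 furthest, both gaps beyond the scatter. For the measured compounds named here, the only step that can be traced within the set is a number 12.6 percentage points lower from compound 1 to compound 3 (beyond the scatter), a modest loss. The change in that pair is at the end of the side chain alone.

Compound 4 `O=C(CN(c1ncnc2c1ncn2C1CCCCO1)C1CC1)NCC(=O)OCc1ccccc1` differs from compound 3 as follows: hydrogen in place of 2-(benzyloxycarbonyl)ethyl on a saturated chain carbon bound to an amide-type nitrogen and a carbonyl carbon. Going by the values given here, no measured step removes this chain outright; the one step known touches only its end, and compound 2, with a shorter side chain on a different core, sits higher than compound 3 but cannot be compared in one step. Removing the 2-(benzyloxycarbonyl)ethyl chain removes the benzyloxy end that coincided with the drop in a number 12.6 percentage points lower from compound 1 to compound 3 (beyond the scatter), so a small recovery at most is expected, direction upward but possibly within the scatter.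

Compound 4 is therefore expected to give 35%, in the range 22% to 50%. The estimated step is a number 9.8 percentage points higher from compound 3 to compound 4 (within the scatter), expected to be small.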

Compound 4, a percentage reported as activity, at one dose (the size of the read-out at that dose, not a potency): 25.9%
The estimate for compound 4 lay 9.1 percentage points above the measured number; the range from low to high includes it.
By their numbers in this assay, from the lowest: compounds 3 and 4 (each within the scatter of the next); then compounds 1 and 2 (each within the scatter of the next).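

In this assay there is a number 0.7 percentage points higher from compound 3 to compound 4 (within the scatter) when hydrogen takes the place of 2-(benzyloxycarbonyl)ethyl on a saturated chain carbon bound to an amide-type nitrogen and a carbonyl carbon, so at this place that chain reads the same as no chain at all. The same replacement of 2-carbamoylethyl gives a number 11.9 percentage points lower from compound 1 to compound 4 (beyond the scatter) and thus, among these compounds, only the 2-carbamoylethyl chain goes with a higher number than hydrogen. Nothing at hand explains this difference between the two chains.

As far as these compounds go, whether the higher number depends on the terminal carbamoyl group or on other chain ends remains open. A carboxylic acid or an amine at the end of the chain, or a longer chain ending in the same carbamoyl group, would test this.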